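A few compounds are considered here, and "the series" means these few. Any claim that something is new, unique, unknown or untested is made for them only; others in the source may bear on it.

The measured compounds:

Compound 1 `O=C(CCCc1ccccc1)Nc1nc2ccccc2c(=O)s1` — in an assay on CHO cells for displacement of a labelled ligand from adenosine receptor A2b (Homo sapiens), read by scintillation counting, with a stated time of 75 min (a lower number here means a stronger inhibitor, a higher number a weaker inhibitor), compound 1 gives > 1000 nM, which is a limit of the assay rather than a number.
Compound 2 `COc1cccc(CCCC(=O)Nc2nc3ccccc3c(=O)s2)c1` — compound 2 gives 302 nM.
Compound 3 `O=C(CCCc1cccc(Cl)c1)Nc1nc2ccccc2c(=O)s1` — compound 3 gives >= 1000 nM, again a limit of the assay.

Compound 1 therefore stands at the limit, the weakest end of what is shown, and only compound 2 returns a measured number. The two limits are set out as the limit of > 1000 nM in this assay, at which 1 of the 3 values shown sits, and (the limit of >= 1000 nM in this assay, at which 1 of the 3 values shown sits).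

Compound 4 `Cc1ccc2nc(NC(=O)CCCc3ccccc3)sc(=O)c2c1` differs from compound 1 by methyl in place of hydrogen on an aromatic carbon. This change sits on the fused ring system of the shared core, whereas all three measured steps alter the phenyl ring of the side chain: an at least 3.3-fold lower number from compound 1 to compound 2 (0.51 log units; beyond the scatter), a step that the two limits leave unreadable from compound 1 to compound 3 and an at least 3.3-fold higher number from compound 2 to compound 3 (0.51 log units; beyond the scatter). None of them touches the core, so they give no direct reading of the step to compound 4; they show only that a substituent on the distant phenyl ring can move the number, and that compound 1 itself is at the limit. With no core-substituted comparison available, the expected step in this assay is a step that the limit leaves unreadable from compound 1 to compound 4, that is, none beyond the scatter.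

Compound 4 is thus estimated at 1500 nM, within 400 nM to 6000 nM, most probably reported as a limit.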

Compound 4, inhibition constant: 408 nM
Compound 4: middle estimate off by 3.7-fold (0.57 log units), on the high side; low and high end bracket the measured number.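

In this assay, a methyl in place of hydrogen on an aromatic carbon of the fused system, meta to a fused ring and para to a fused ring, gives an at least 2.4-fold lower number from compound 1 to compound 4 (0.38 log units; beyond the scatter). Among the compounds shown here, this is the first reading of a change on the shared core rather than on the phenyl ring of the side chain, and it shows that a single added carbon at this position is enough to bring compound 4 to a measured number, where the unsubstituted compound 1 gives none. The true size of the step stays unknown because only one end of it is a number: the limit of > 1000 nM in this assay, at which 1 of the 4 values shown sits.

The compounds shown hold just this one group at this one place on the core, so it remains open whether an ethyl, a methoxy, a chloro, an amine or a carboxylic acid at the same carbon would shift the number in the same way, or whether the methyl would do so at another carbon of the fused system. Also open, from the compounds shown here alone, is whether the methyl on the core and the methoxy of compound 2 would add up when placed in one molecule.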